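The source may hold more compounds than are shown below. What is called first, only, known or untested is meant among the compounds shown, and "the series" means these compounds.

Measured compounds:
- compound 1 `CC(C)OC(=O)N1CCC(Oc2cccc3c2CCN3c2ccc(S(C)(=O)=O)cc2)CC1`: 70%
- compound 2 `CC(C)OC(=O)N1CCC(Oc2ncnc3c2CCN3c2ccc(-c3cccn3C)cc2F)CC1`: 44%
- compound 3 `CCOC(=O)N1CCC(Oc2ncnc3c2CCN3c2ccc(S(C)(=O)=O)cc2F)CC1`: 135%

In a functional assay on CHO-K1 cells with Glucose-dependent insulinotropic receptor (Homo sapiens) as the target, read by a luciferase reporter, with a stated time of 5 h (on this read-out lower numbers stand for smaller maximal responses and higher numbers for larger maximal responses), compound 3 gives the highest of the three numbers recorded. Its nearest neighbour on this read-out is compound 1, whose value in this assay is 70%, a gap beyond the scatter; compound 2 stands furthest away with 44%, also beyond the scatter. Among the compounds with values here, compound 3 is therefore the largest maximal response measured so far. The three compounds differ from one another in more than one place, so no single change can be read from these numbers.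

Compound 4 `COCCOC(=O)N1CCC(Oc2ncnc3c2CCN3c2ccc(S(C)(=O)=O)cc2F)CC1` has not yet been measured in this assay. It keeps the whole of compound 3 apart from one change on the carbamate chain: methoxy in place of hydrogen on a saturated chain carbon, two bonds along the chain from an oxygen next to a carbonyl group. Read one bond further out, the ethyl of the carbamate becomes a 2-methoxyethyl.

A change of this kind, on a chain remote from the ring portion, is expected to move the maximal response little. The step from compound 3 to compound 4 is expected to be a number 17 percentage points lower from compound 3 to compound 4 (beyond the scatter), that is within or just at the edge of the scatter, with a slight lean toward a smaller response because compound 3 already sits at 135%. Compound 4 is therefore estimated at 118%, with a range from 85% to 150%.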

Compound 4, largest response reached (reported as percent of maximum), in percent of the reference or control that the assay uses: 86%
Compound 4: middle estimate off by 32 percentage points, on the high side; measured number inside the range.
By their numbers in this assay, from the lowest: compound 2; then compound 1; then compound 4; then compound 3.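

In this assay, within the data shown here, methoxy in place of hydrogen on a saturated chain carbon, two bonds along the chain from an oxygen next to a carbonyl group, gives a number 49 percentage points lower from compound 3 to compound 4 (beyond the scatter) and is the first step that changes one place only. The earlier compounds shown here differed in more than one place and could not isolate the carbamate chain, whereas this pair shows that the maximal response can shift substantially when ethyl becomes 2-methoxyethyl, even though the shared core stays untouched. No measurement at hand bears on why the response falls with this change.

The compounds shown do not separate the contribution of the chain oxygen from that of the chain's extra length, a question that a plain butyl chain, a 2-hydroxyethyl or a 2-aminoethyl group at the same place could address. As far as these compounds go, it also remains open whether the same step would carry over to a carbamate on a different core, or whether it holds only alongside the other groups of compound 3.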